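Ring for Methyl: Expected Gain on the Ghrelin Receptor Target

A few compounds are considered here, and "the series" means these few. Any claim that something is new, unique, unknown or untested is made for them only; others in the source may bear on it.

Measured compounds:
compound 1 `CCCc1onc(-c2c(Cl)cccc2Cl)c1C(=O)Nc1ccc(N(CC)CC)cc1`: 492 nM
compound 2 `CCN(CC)c1ccc(NC(=O)c2c(-c3c(Cl)cccc3Cl)noc2CCC2OCCCO2)cc1`: 19 nM

In a functional assay on CHO-K cells with growth hormone secretagogue receptor type 1 (Homo sapiens) as the target, read by FLIPR (a higher number here means a weaker inhibitor, a lower number a stronger inhibitor), compound 1 gives 492 nM, the highest of the two numbers shown. Compound 3 `CCN(CC)c1ccc(NC(=O)c2c(-c3c(Cl)cccc3Cl)noc2CCC2CCCCO2)cc1` differs from compound 1 by oxan-2-yl in place of methyl on a saturated chain carbon, two bonds along the chain from an aromatic carbon. Going by the values given here, the one step that bears on this is a 26-fold lower number from compound 1 to compound 2 (1.41 log units; beyond the scatter), where a closely related six-membered ring with two heteroatoms entered at the same place. A step of similar direction, somewhat smaller, is therefore expected for compound 3, read as a 14-fold lower number from compound 1 to compound 3 (1.15 log units; beyond the scatter). Compound 3 is estimated at 35 nM, with a range from 10 nM to 120 nM.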

Compound 3, half-maximal inhibitory concentration: 102 nM
Compound 3: the middle estimate sits 2.9-fold (0.46 log units) below what was measured, and the stated range covers the measured number.
By their numbers in this assay, from the lowest: compound 2; then compound 3; then compound 1.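

In this assay, oxan-2-yl at this place keeps part of the gain over methyl, with a 4.8-fold lower number from compound 1 to compound 3 (0.68 log units; beyond the scatter), so the oxan-2-yl ring is enough for a real improvement. The ring with 2 hetero atoms still does better, since the change to oxan-2-yl gives a 5.4-fold higher number from compound 2 to compound 3 (0.73 log units; beyond the scatter). No measurement here explains this difference between the two rings. Going by these compounds, it remains open whether cyclohexyl, with no ring oxygen, would keep any of the gain. Piperidin-2-yl, with a ring nitrogen, and a longer chain carrying the oxan-2-yl ring are also untested in the compounds shown.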